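The source may report more compounds than this note shows. Statements on the series, on what has been measured and on what is new or still open speak of the compounds shown alone.

Compound 1 `CCCCC(=O)Oc1cc(/C=C/C(=O)c2ccc(OC)c3c2OC(C)(C)C=C3)ccc1OC` gives 220 nM in a functional assay on A-375 cells (Homo sapiens) for cytotoxicity, read by MTT assay (a lower number here means a stronger inhibitor, a higher number a weaker inhibitor), the lowest of the two numbers shown. Compound 2 `COc1ccc(/C=C/C(=O)Oc2cc(/C=C/C(=O)c3ccc(OC)c4c3OC(C)(C)C=C4)ccc2OC)cc1` gives 2630 nM in this assay. For the measured compounds named here, the only measured step, a 12-fold higher number from compound 1 to compound 2 (1.08 log units; beyond the scatter), put 2-(4-methoxyphenyl)ethenyl in place of butyl on a carbonyl carbon. Compound 3 `COc1ccc(/C=C/C(=O)c2ccc(OC)c3c2OC(C)(C)C=C3)cc1OS(=O)(=O)Cc1ccccc1` differs from compound 1 by benzylsulfonyl in place of butylcarbonyl on an oxygen on an aromatic ring. This change likewise brings in one six-membered aromatic ring of carbon only, though through a different connecting group, so a smaller rise than in that step is expected. Compound 3 is estimated at 600 nM in this assay, within 200 nM to 2000 nM. The expected step is a 2.7-fold higher number from compound 1 to compound 3 (0.44 log units; beyond the scatter).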

Compound 3, half-maximal inhibitory concentration: > 10000 nM
Compound 3: no number, only a limit; the forecaster's own chance of this, stated with the estimate: 5%; at least 16-fold (1.22 log units) between middle value and limit.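

In this assay compound 3 gives > 10000 nM, which is a limit and not a number. Placing benzylsulfonyl on this oxygen gives an at least 45-fold higher number from compound 1 to compound 3 (1.65 log units; beyond the scatter), and set against the ring-bearing ester it gives an at least 3.8-fold higher number from compound 2 to compound 3 (0.58 log units; beyond the scatter). The position therefore separates two groups that each bring in a six-membered aromatic ring of carbon only, so that ring alone does not set the outcome. As far as these compounds go, what stays open is whether the sulfonyl link or the benzyl part carries this loss; a butylsulfonyl group on the same oxygen would separate the two.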